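Swapping a hydroxypropyl chain for a hydroxycyclohexyl ring

The source may report more compounds than this note shows. Statements on the series, on what has been measured and on what is new or still open speak of the compounds shown alone.

Three compounds share one core and differ only in the group on the amino nitrogen. In an assay on isolated protein for binding affinity to adenosine receptor A1 (Bos taurus) (a lower number here means a stronger inhibitor, a higher number a weaker inhibitor), compound 1 `CNc1nc(-c2ccccc2)nc2c1nnn2Cc1ccccc1Cl` gives 191000000 nM. Compound 2 `CCNc1nc(-c2ccccc2)nc2c1nnn2Cc1ccccc1Cl` gives 463000000 nM, and compound 3 `OCCCNc1nc(-c2ccccc2)nc2c1nnn2Cc1ccccc1Cl` gives 33000000 nM, the lowest of the three numbers. The step of a 5.8-fold lower number from compound 1 to compound 3 (0.76 log units; beyond the scatter) and the step of a 14-fold lower number from compound 2 to compound 3 (1.15 log units; beyond the scatter) both run toward a lower number, whereas the step of a 2.4-fold higher number from compound 1 to compound 2 (0.38 log units; beyond the scatter) runs the other way.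

Compound 4 `OC1CCC(Nc2nc(-c3ccccc3)nc3c2nnn3Cc2ccccc2Cl)CC1` carries the change (4-hydroxycyclohexyl in place of 3-hydroxypropyl on a nitrogen on an aromatic ring). Among the measured compounds shown here, no measured step exchanges a chain for a ring on this nitrogen, so the two hydroxyl-bearing steps are the only guide; in both, the group carrying a hydroxyl gave a lower number than the smaller groups of compound 1 and compound 2. Because compound 3 gives 33000000 nM and compound 4 keeps a hydroxyl-bearing group, compound 4 is expected to show a 2.2-fold lower number from compound 3 to compound 4 (0.34 log units; beyond the scatter). Compound 4 is estimated at 15000000 nM, with a range from 3000000 nM to 80000000 nM.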

Compound 4, inhibition constant: 3100000 nM
Beside the measured number, compound 4's estimate is 4.8-fold (0.68 log units) above it, and the stated range covers the measured number.
By their numbers in this assay, from the lowest: compound 4; then compound 3; then compound 1; then compound 2.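

In this assay, an 11-fold lower number from compound 3 to compound 4 (1.03 log units; beyond the scatter) shows that at this nitrogen the number depends on more than the presence of a hydroxyl, since 3-hydroxypropyl and 4-hydroxycyclohexyl both carry one yet lie far apart. The distance to the smaller groups is wider still, with a 62-fold lower number from compound 1 to compound 4 (1.79 log units; beyond the scatter) and a 150-fold lower number from compound 2 to compound 4 (2.17 log units; beyond the scatter), which puts compound 4 lowest of the four and makes the six-membered non-aromatic ring the largest single change seen at this position. Nothing available here offers an explanation for this gain.

A plain cyclohexyl group would show whether the ring alone accounts for the drop or whether its hydroxyl still contributes. On these data alone, it also remains open whether a cyclopentyl ring or a 4-aminocyclohexyl group would follow compound 4.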